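The compounds below may be only part of what the source reports. "The series", "measured", "known", "first", "only" and "open" are said of these compounds alone.

Compound 1 `CCCc1nc(-c2ccccc2)c(CNCCN2CCN(c3cccc(C(F)(F)F)c3)CC2)o1`, compound 2 `CCCc1nc(-c2ccccc2)c(CNCCN2CCN(c3ccc(F)cc3)CC2)o1` and compound 3 `CCCc1nc(-c2ccccc2)c(CNCCN2CCN(c3ccccc3C(F)(F)F)CC2)o1` share one core and differ only in the aromatic group carried on an amine nitrogen in a ring. In an assay on HEK293 cells for inhibition of Voltage-dependent T-type calcium channel subunit alpha-1G (Homo sapiens), read by patch clamp (on this read-out higher numbers stand for weaker inhibition and lower numbers for stronger inhibition), compound 1 gives 1940 nM, compound 2 gives 7080 nM and compound 3 gives 2100 nM. Compound 3 thus holds the second highest of the three numbers: its number and that of compound 1 lie within the scatter of each other, while compound 2 lies beyond it, as the step of a 3.4-fold lower number from compound 2 to compound 3 (0.53 log units; beyond the scatter) shows. Compound 4 `CCCc1nc(-c2ccccc2)c(CNCCN2CCN(c3ccc(C(F)(F)F)cc3)CC2)o1` has not yet been measured in this assay. The change from compound 3 is 4-(trifluoromethyl)phenyl in place of 2-(trifluoromethyl)phenyl on an amine nitrogen in a ring. Two kinds of measured step bear on it. The step of a 1.1-fold higher number from compound 1 to compound 3 (0.03 log units; within the scatter) shows that carrying the trifluoromethyl group at a different ring position gave a step within the scatter. The steps of a 3.6-fold higher number from compound 1 to compound 2 (0.56 log units; beyond the scatter) and a 3.4-fold lower number from compound 2 to compound 3 (0.53 log units; beyond the scatter) set a 4-fluorophenyl against trifluoromethylphenyl groups and were modest. Keeping the trifluoromethyl group, now as 4-(trifluoromethyl)phenyl, is therefore expected to move the number little, if at all beyond the scatter. Compound 4 is expected to give about 2500 nM in this assay, between 1000 nM and 6500 nM. The step expected is a 1.2-fold higher number from compound 3 to compound 4 (0.08 log units; within the scatter).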

Compound 4, half-maximal inhibitory concentration: 1300 nM
For compound 4 the middle estimate is 1.9-fold (0.28 log units) above the measured one, and the stated range covers the measured number.
By their numbers in this assay, from the lowest: compounds 4, 1 and 3 (each within the scatter of the next); then compound 2.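

With compound 4 in hand, the trifluoromethyl group has been seen in the 2-, 3- and 4-(trifluoromethyl)phenyl forms, and in this assay the new form stays close to both others: a 1.6-fold lower number from compound 3 to compound 4 (0.21 log units; within the scatter) and a 1.5-fold lower number from compound 1 to compound 4 (0.17 log units; within the scatter). Among these three compounds, then, moving the group around the aromatic ring gives no step beyond the scatter. Compound 4 also supplies the cleanest comparison with compound 2. The group changes while its ring position stays the same, and this exchange of fluoro for trifluoromethyl gives a 5.4-fold lower number from compound 2 to compound 4 (0.74 log units; beyond the scatter), a modest change that shows the group itself matters here, although nothing available explains the size of this step.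

Fluoro appears only as 4-fluorophenyl, so it remains open whether its number would also hold steady at other ring positions, and whether chloro, methoxy or nitrile at the same place would track compound 4 or compound 2. On these data alone, the effect of changes elsewhere, such as a longer chain in place of the propyl group on the shared core, also remains open.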